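A few compounds are considered here, and "the series" means these few. Any claim that something is new, unique, unknown or untested is made for them only; others in the source may bear on it.

Compound 1 `CCCSc1nc(N/N=C/c2cccnc2)c2nnn(Cc3ccccc3)c2n1` is the only one of the three measured compounds to return a number. In a functional assay on MCF7 cells (Homo sapiens) for antiproliferative activity, read by MTT assay, with a stated time of 72 h (on this read-out higher numbers stand for weaker inhibition and lower numbers for stronger inhibition), compound 1 gives 58700 nM. Compound 2 `CCCSc1nc(N/N=C/c2ccc(Cl)cc2)c2nnn(Cc3ccccc3)c2n1` reaches only a limit of the assay, > 64000 nM. Compound 3 `CCCSc1nc(N/N=C/c2ccc(Br)cc2)c2nnn(Cc3ccccc3)c2n1` likewise reaches only a limit of the assay, > 64000 nM. Compound 3 therefore stands at the edge of what the assay can report, sharing that position with compound 2, and the shared limit is the limit of > 64000 nM in this assay, at which 2 of the 3 values shown sit. Compound 4 `CCCSc1nc(N/N=C/c2ccc3ccccc3c2)c2nnn(Cc3ccccc3)c2n1` differs from compound 3 in a single place: naphthalen-2-yl in place of 4-bromophenyl on a carbon with a double bond to nitrogen. Among the compounds with values here, two measured steps bear on this position. The step of an at least 1.0-fold higher number from compound 1 to compound 3 (0.03 log units; that floor lies within the scatter) exchanges the aryl group on the same carbon, and the step that the two limits leave unreadable from compound 2 to compound 3 exchanges a halogen on that aryl group; neither step produced a readable number, and every aryl group tried on this carbon has left the compound weak or unreadable. The step that the limit leaves unreadable from compound 3 to compound 4 is accordingly expected to be small or unreadable in either direction, with compound 4 expected to remain weak. Compound 4 is estimated to give about 70000 nM, most likely between 25000 nM and 200000 nM, with a considerable chance that the assay reports only a limit again.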

Compound 4, half-maximal inhibitory concentration: > 64000 nM
Compound 4 was reported as a limit; the forecaster's own chance of this, stated with the estimate: 60%; the middle value lies beyond the limit too.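

In this assay, compound 4 also ends at a limit, which shows that a halogen on the aryl group is not needed to reach that limit: naphthalen-2-yl, with two six-membered aromatic rings of carbon only and no bromine or chlorine, gives no readable number either. Within the data shown here, the only step that can be read is an at least 1.0-fold higher number from compound 1 to compound 4 (0.03 log units; that floor lies within the scatter), so pyridin-3-yl remains the only group on this carbon to return a number, but the data do not place compound 1 ahead of compound 4 beyond the scatter. The steps to compound 4 from compound 2 and from compound 3 cannot be read, because all three compounds share the same limit: the limit of > 64000 nM in this assay, at which 3 of the 4 values shown sit.

The compounds shown leave open whether an aryl group on this carbon that carries an amine or a carboxylic acid would give a number clearly stronger than that of compound 1, at 58700 nM. They also do not show whether a change elsewhere on the shared core, such as a longer chain on the sulfur, would bring compound 4 back within the range of this assay.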